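Methoxy in place of fluoro: notes toward compound 3

The source may report more compounds than this note shows. Statements on the series, on what has been measured and on what is new or still open speak of the compounds shown alone.

compound 1 `COc1ccc(N(C)Cc2nc3cc(C(F)(F)F)ccc3nc2-c2ccccc2)cc1`: 3000 nM
compound 2 `C#CCN(Cc1nc2cc(C(F)(F)F)ccc2nc1-c1ccccc1)c1ccc(F)cc1`: 8000 nM

In an assay on isolated protein for inhibition of Dihydrofolate reductase (Homo sapiens), read by spectrophotometry (a lower number here means a stronger inhibitor, a higher number a weaker inhibitor), compound 1 gives 3000 nM and compound 2 gives 8000 nM. Compound 2 stands highest of the two numbers, with compound 1 its nearest neighbour, and that gap lies beyond the scatter. Compound 3 `C#CCN(Cc1nc2cc(C(F)(F)F)ccc2nc1-c1ccccc1)c1ccc(OC)cc1` differs from compound 2 by methoxy in place of fluoro on an aromatic carbon. For the measured compounds named here, no pair of measured compounds isolates this change; compound 1 carries the methoxy but differs from compound 2 elsewhere as well, so the two values only show the methoxy-bearing compound with the lower number. The expected step is a 1.8-fold lower number from compound 2 to compound 3 (0.25 log units; within the scatter), a modest move toward a lower number, with direction uncertain. Compound 3 is estimated at 4500 nM, range 1500 nM to 13000 nM.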

Compound 3, inhibition constant: 3000 nM
For compound 3 the middle estimate is 1.5-fold (0.18 log units) above the measured one; the range from low to high includes it.
By their numbers in this assay, from the lowest: compounds 1 and 3 (each within the scatter of the next); then compound 2.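

In this assay, the change from 4-fluorophenyl to 4-methoxyphenyl now reads on its own as a 2.7-fold lower number from compound 2 to compound 3 (0.43 log units; beyond the scatter) with the rest of the structure held constant. With the methoxy held constant, ethynyl in place of hydrogen on the saturated chain carbon gives no change at the digits printed from compound 1 to compound 3 (within the scatter) as its step. Across these three compounds, the number therefore follows the methoxy or fluoro group and not the ethynyl. Nothing at hand accounts for either step.

As far as these compounds go, whether a hydroxyl, an amine or a longer alkoxy chain at this position would shift the number remains open. So does whether the methoxy step holds when hydrogen replaces the ethynyl.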